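Methyl in Place of Methoxy: Cytotoxicity Expected to Stay Unchanged

This account rests on a few compounds, and the source may have more. Where it says the series, first, only, none or still open, it means among the compounds named here.

The three measured compounds share one core. Compound 2 `COc1ccc(NC(=O)Nc2cc(C)nc3ccccc23)cc1` carries a methoxy group. In an ADME assay on Raji cells (Homo sapiens) for cytotoxicity, with a stated time of 72 h (on this read-out higher numbers stand for an effect only at larger amounts of compound and lower numbers for an effect already at smaller amounts), compound 2 gives > 25000 nM, which is a limit of the assay and not a number. Compound 3 `COc1ccc(NC(=O)Nc2cc(C)nc3ccccc23)cc1F` differs from compound 2 by fluoro in place of hydrogen on an aromatic carbon. In this assay compound 3 gives > 25000 nM, again a limit. The step that the two limits leave unreadable from compound 2 to compound 3 is therefore unreadable. Compound 1 `Cc1cc(NC(=O)Nc2ccc([N+](=O)[O-])c(C(F)(F)F)c2)c2ccccc2n1`, bearing a nitro and a trifluoromethyl group, gives > 25000 nM in this assay, also a limit. Among the measured compounds shown here, the whole evidence is thus (the limit of > 25000 nM in this assay, at which 3 of the 3 values shown sit); no measured step has a readable size.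

Compound 4 `Cc1ccc(NC(=O)Nc2cc(C)nc3ccccc23)cc1` differs from compound 2 by methyl in place of methoxy on an aromatic carbon. For the measured compounds named here, no measured step bears on this change. Because compound 2 sits at the limit > 25000 nM, compound 4 is expected to sit at the limit as well, with a step that the limit leaves unreadable from compound 2 to compound 4 that cannot be read beyond the scatter. Compound 4 is estimated at 40000 nM, in a range from 12000 nM to 130000 nM.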

Compound 4, half-maximal effective concentration: > 25000 nM
Compound 4: only a limit was reported; the forecaster's own chance of this, stated with the estimate: 85%; the middle value is on the limit's open side.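

The step from compound 2 to compound 4 cannot be read in this assay, as both values are limits of the assay and not numbers. The compounds shown leave open at what concentration any of them would produce a half-maximal cytotoxic effect.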